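The source may hold more compounds than are shown below. What is called first, only, known or untested is meant among the compounds shown, and "the series" means these compounds.

Compound 1 `CC1(C)C=C(n2ccccc2=O)c2cc(C(=O)c3ccccc3)ccc2O1` stands highest of the two numbers in hand: in a functional assay (aorta) with Rattus norvegicus as the target (a higher number here means a more potent compound, by a factor of ten per unit of this negative logarithm, a lower number a less potent compound), compound 1 gives 6.61, while compound 2 `CC1(C)C=C(n2ccccc2=O)c2cc(OC(=O)Nc3ccccc3)ccc2O1` gives 5.3, a gap beyond the scatter. Compound 3 `CC1(C)C=C(n2ccccc2=O)c2cc(C#N)ccc2O1` differs from compound 1 in one place, (cyano in place of benzoyl on an aromatic carbon), the benzoyl leaving and the cyano entering on that aromatic carbon. Going by the values given here, no step between measured compounds is known for this change, so the direction is open; a modest rise, or none beyond the scatter, is expected here. Compound 3 is estimated at 6.9 in this assay, between 6.2 and 7.6, which as a step would mean a number 0.29 log units higher from compound 1 to compound 3 (within the scatter).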

Compound 3, logarithm of the reciprocal of the active concentration, log(1/C): 7.67
Compound 3: the middle estimate sits 0.77 log units below what was measured; the measured number lies above the stated range.
By their numbers in this assay, from the lowest: compound 2; then compound 1; then compound 3.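

Going by these compounds alone, putting cyano in place of benzoyl on this aromatic carbon gives a number 1.06 log units higher from compound 1 to compound 3 (beyond the scatter) in this assay, the largest number so far. The position therefore does not need the benzoyl's six-membered aromatic ring to reach a high number, and a group with no ring serves it better here. Nothing at hand explains why this change raises the number.

On these data alone, it remains open whether the rise belongs to cyano itself or would also come with another small group on this carbon, such as a nitro group, an amine or a carboxylic acid.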